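From 2-chlorophenyl to 4-methylbenzyl on the amide nitrogen

The compounds below may be only part of what the source reports. "The series", "measured", "known", "first", "only" and "open" are said of these compounds alone.

In a functional assay on QGY cells (Homo sapiens) for cytotoxicity, read by MTT assay, with a stated time of 48 h (on this read-out higher numbers stand for weaker inhibition and lower numbers for stronger inhibition), compound 2 `COc1cc([C@H]2C[C@@]2(CO)C(=O)Nc2ccccc2Cl)cc(OC)c1OC` reads > 100000 nM, which is a limit of the assay and not a number. Compound 3 `COc1cc([C@H]2C[C@@]2(CO)C(=O)NCc2ccc(C)cc2)cc(OC)c1OC` shares the core of compound 2 and differs in the group on the amide: 4-methylbenzyl in place of 2-chlorophenyl on an amide-type nitrogen. In words, 4-methylbenzyl takes the place of 2-chlorophenyl on an amide-type nitrogen. The same 4-methylbenzyl group sits on a stereoisomer of compound 3, namely compound 1 `COc1cc([C@H]2C[C@]2(CO)C(=O)NCc2ccc(C)cc2)cc(OC)c1OC`, which gives 56100 nM in this assay. A small step towards stronger inhibition is therefore expected in this assay, resting on compound 1 at 56100 nM. The reading for compound 3 could again prove to be a limit. The estimated change is an at least 1.2-fold lower number from compound 2 to compound 3 (0.09 log units; that floor lies within the scatter). For compound 3 the expected value is 80000 nM, with an estimated range from 30000 nM to 200000 nM.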

Compound 3, half-maximal inhibitory concentration: > 100000 nM
Compound 3 ended at the assay's limit; the forecaster's own chance of this, stated with the estimate: 40%; middle value at least 1.2-fold (0.09 log units) from the limit.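

With 4-methylbenzyl in place of 2-chlorophenyl on an amide-type nitrogen, the change itself cannot be read, because both compounds sit at a limit of the assay and neither reading is a number: the limit of > 100000 nM in this assay, at which 2 of the 3 values shown sit. The new information comes from the stereoisomer pair, which in this assay gives an at least 1.7-fold higher number from compound 1 to compound 3 (0.25 log units; that floor lies within the scatter). This floor does not establish that the drawn configuration matters, but the 4-methylbenzyl amide gives a measured value only in compound 1, and the pair isolates that stereocentre as the sole structural difference: the fact that compounds 1 and 3 differ only in the configuration as drawn.

On these data alone, it remains open whether any group on this nitrogen gives a measurable value in the configuration shared by compound 2 and compound 3. As far as these compounds go, what a phenethyl or 4-fluorobenzyl group would read there also remains open.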